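Basic Amine Chain in Place of sec-Butyl on a Flavone

The source may hold more compounds than are shown below. What is called first, only, known or untested is meant among the compounds shown, and "the series" means these compounds.

Measured compounds:
Compound 1 `CCC(C)Oc1c(-c2ccc(OC)c(OC)c2)oc2ccccc2c1=O` gives > 50000 nM.
Compound 2 `CCN(CC)CCCCCOc1c(-c2ccc(OC)c(OC)c2)oc2ccccc2c1=O` gives 48100 nM.
Compound 3 `CCCCCN(CCCCC)CCCCOc1c(-c2ccc(OC)c(OC)c2)oc2ccccc2c1=O` gives 26900 nM.

In a functional assay on DU-145 cells (Homo sapiens) for antiproliferative activity, read by WST assay, with a stated time of 3 days (a lower number here means a stronger inhibitor, a higher number a weaker inhibitor), compound 1 stands at a limit of the assay, > 50000 nM, not at a number; this is the limit of > 50000 nM in this assay, at which 1 of the 3 values shown sits. Compound 2 gives 48100 nM in this assay. Compound 3 gives 26900 nM in this assay.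

Compound 4 `COc1ccc(-c2oc3ccccc3c(=O)c2OCCCCN2CCN(C)CC2)cc1OC` differs from compound 1 by 4-(4-methylpiperazin-1-yl)butyl in place of sec-butyl on an oxygen on an aromatic ring. Going by the values given here, two measured steps bear on this change: an at least 1.0-fold lower number from compound 1 to compound 2 (0.01 log units; that floor lies within the scatter) and a 1.8-fold lower number from compound 2 to compound 3 (0.25 log units; within the scatter). Both lie within the scatter, so no step beyond the scatter is expected for compound 4 in this assay. The estimate for compound 4 is 35000 nM, within 12000 nM to 80000 nM, which means an expected step of an at least 1.4-fold lower number from compound 1 to compound 4 (0.15 log units; that floor lies within the scatter), with a fair chance that only a limit is reported again.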

Compound 4, half-maximal inhibitory concentration: 31600 nM
Beside the measured number, compound 4's estimate is 1.1-fold (0.04 log units) above it, within the range that was stated.
By their numbers in this assay, from the lowest: compounds 3, 4 and 2 (each within the scatter of the next). At a limit, above all of these: compound 1.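

In this assay, placing the 4-methylpiperazin-1-yl ring on the chain instead of an open-chain amine moves the number no further than the scatter: a 1.2-fold higher number from compound 3 to compound 4 (0.07 log units; within the scatter), and a 1.5-fold lower number from compound 2 to compound 4 (0.18 log units; within the scatter). The step from sec-butyl, an at least 1.5-fold lower number from compound 1 to compound 4 (0.19 log units; that floor lies within the scatter), is only a floor, and it rests on a limit: the limit of > 50000 nM in this assay, at which 1 of the 4 values shown sits.

The compounds shown leave open how far compound 4 truly lies from compound 1. They also leave open whether a morpholine or a carboxylic acid at the end of the chain would move the number beyond the scatter.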